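The compounds below may be only part of what the source reports. "The series", "measured", "known", "first", "only" and "open" are said of these compounds alone.

In a functional assay on MCF7 cells (Homo sapiens) for antiproliferative activity, read by CCK-8 assay, with a stated time of 72 h (a higher number here means a weaker inhibitor of growth, a lower number a stronger inhibitor of growth), compound 1 `CCCCNS(=O)(=O)c1ccc(Nc2ncc3c(n2)N(C2CCCC2)[C@H](CC)C(=O)N3C)cc1` gives 459 nM. Among the compounds with values here, this is the lower of the two numbers measured so far, and so the stronger growth inhibition. The other number belongs to compound 2 `CCC1C(=O)N(C)c2cnc(-n3ccc4cc(F)ccc43)nc2N1c1ccn(C)n1`, which gives 24700 nM, and the gap between the two lies well beyond the usual scatter of repeated measurements. Within the data shown here, no two measured compounds differ in just one place, so the data offer no direct guide to the effect of a single small change.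

The next molecule, compound 3 `CC[C@@H]1C(=O)N(C)c2cnc(Nc3ccc(S(=O)(=O)NCC(C)C)cc3)nc2N1C1CCCC1`, has yet to be measured in this assay. Its structure departs from compound 1 in the chain on the sulfonamide: isopropyl in place of propyl on a saturated chain carbon bound to a sulfonamide nitrogen. In words, isopropyl stands in place of propyl on a saturated chain carbon bound to a sulfonamide nitrogen, so that butyl becomes isobutyl. Among the measured compounds shown here, with no measured precedent for this swap, no direction is favoured, and only a small change is expected. The estimated step of a 1.0-fold higher number from compound 1 to compound 3 (0.00 log units; within the scatter) is expected to stay within the scatter. Compound 3 is expected to give about 460 nM, with an estimated range of 180 nM to 1200 nM.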

Compound 3, concentration for 50% growth inhibition: 403 nM
For compound 3 the middle estimate is 1.1-fold (0.06 log units) above the measured one; low and high end bracket the measured number.
By their numbers in this assay, from the lowest: compounds 3 and 1 (each within the scatter of the next); then compound 2.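

Within the data shown here, this is the first pair of measured compounds that differ in one place, so the sulfonamide chain can now be judged on its own: in this assay, going from butylsulfamoyl to isobutylsulfamoyl gives a 1.1-fold lower number from compound 1 to compound 3 (0.06 log units; within the scatter). The two chains have the same atoms joined differently, so moving from a straight chain to a branched one at this position leaves the growth-inhibition reading unchanged within the scatter, at least for this one pair. No measurement shown here accounts for that outcome.

Going by these compounds, a single branch on a chain of this size says little about how much change the position can take, so it remains open whether a longer chain, a cyclopropylmethyl group, or a chain ending in an amine or a carboxylic acid would keep the same reading. On these data alone, the cyclopentyl and ethyl groups on the shared core also stay the same in compound 1 and compound 3, so what they contribute remains unknown, and this result cannot be assumed to hold if either of them is replaced.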